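This account rests on a few compounds, and the source may have more. Where it says the series, first, only, none or still open, it means among the compounds named here.

Measured compounds:
- compound 1, `COc1cc(/C=C/C=C/C(=O)O)ccc1O`: 19700 nM in a physicochemical assay, read by spectrophotometry; on this read-out lower numbers stand for stronger inhibition and higher numbers for weaker inhibition
- compound 2, `O=C(O)/C=C/C=C/c1ccc(O)c(O)c1`: 11100 nM in this assay

Compound 1 stands at the highest of the two numbers recorded in this assay; its nearest neighbour is compound 2, reached by a 1.8-fold lower number from compound 1 to compound 2 (0.25 log units; within the scatter), a step that stays within the scatter of the assay.

Compound 3, `COc1ccc(/C=C/C=C/C(=O)O)cc1OC`, has not yet been measured in this assay. It differs from compound 1 by methyl in place of hydrogen on an oxygen on an aromatic ring. Going by the values given here, only one measured step bears on this change: the step from compound 1 to compound 2 exchanges hydrogen for methyl on an oxygen on an aromatic ring, the mirror image of the change now considered, and it amounts to a 1.8-fold lower number from compound 1 to compound 2 (0.25 log units; within the scatter), which does not exceed the scatter. On that basis the present change is expected to move the number little, if at all, and if anything toward a higher value.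

Compound 3 is therefore expected to give about 28000 nM in this assay, within a range from 12000 nM to 70000 nM. This estimate amounts to an expected step of a 1.4-fold higher number from compound 1 to compound 3 (0.15 log units; within the scatter).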

Compound 3, half-maximal inhibitory concentration: > 50000 nM
Compound 3: a limit, no number; the forecaster's own chance of this, stated with the estimate: 10%; middle value at least 1.7-fold (0.25 log units) away from the limit.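

In this assay, the earlier change at a ring oxygen, hydrogen for methyl in going from the methoxy of compound 1 to a hydroxy, stayed within the scatter (a 1.8-fold lower number from compound 1 to compound 2 (0.25 log units; within the scatter)). Compound 3 shows that the other oxygen on the aromatic ring, the one that carries hydrogen in compound 1, does not behave the same way: hydroxy to methoxy there gives a change beyond the scatter (an at least 2.5-fold higher number from compound 1 to compound 3 (0.40 log units; beyond the scatter)). The value of compound 3 is a limit of the assay and not a number, so this step gives a lower bound on the change and not its size: the limit of > 50000 nM in this assay, at which 1 of the 3 values shown sits.

The compounds shown therefore leave open how far the number rises with methoxy at this oxygen, and whether the loss follows from the methyl itself or from the loss of the hydrogen on that oxygen. They also leave open what a longer chain such as ethyl, an acetyl group or an amine at this place would do, and whether a methyl ester or an amide in place of the carboxylic acid would change the picture.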